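From 3-hydroxybenzyl to 4-hydroxycyclohexyl at an assay limit

The source may hold more compounds than are shown below. What is called first, only, known or untested is meant among the compounds shown, and "the series" means these compounds.

In a functional assay on HL-60 cells (Homo sapiens) for inhibition, read by CCK-8 assay, with a stated time of 48 h (on this read-out lower numbers stand for stronger inhibition and higher numbers for weaker inhibition), compound 1 `O=S(=O)(NCCNC(=S)Nc1cc(C(F)(F)F)cc(C(F)(F)F)c1)c1ccc(-c2ccccc2OCc2cccc(O)c2)s1` stands at > 50000 nM and this is a limit of the assay, not a number. In this assay compound 2 `COc1cccc(NC(=O)NCCNS(=O)(=O)c2ccc(-c3ccccc3OCc3ccccc3)s2)c1` gives 1700 nM as a measured number. Compound 3 `O=S(=O)(NCCNC(=S)Nc1cc(C(F)(F)F)cc(C(F)(F)F)c1)c1ccc(-c2ccccc2O[C@H]2CC[C@@H](O)CC2)s1` carries 4-hydroxycyclohexyl in place of 3-hydroxybenzyl on an oxygen on an aromatic ring, a swap that counts as 4-hydroxycyclohexyl in place of 3-hydroxybenzyl on an oxygen on an aromatic ring against compound 1. Within the data shown here, no measured step covers this swap, so only a small gain in inhibition is expected in this assay and the read-out may again be a limit. The expected move is an at least 1.6-fold lower number from compound 1 to compound 3 (0.22 log units; that floor lies within the scatter) and no more. Compound 3 is estimated at 30000 nM with 6000 nM to 100000 nM as its range.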

Compound 3, half-maximal inhibitory concentration: 2600 nM
Estimate against measurement, compound 3: 12-fold (1.06 log units) above; measured number below the stated range.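

In this assay, 4-hydroxycyclohexyl in place of 3-hydroxybenzyl on an oxygen on an aromatic ring gives an at least 19-fold lower number from compound 1 to compound 3 (1.28 log units; beyond the scatter), which shows that inhibition at this position responds to the group it carries. Compound 1 stands at > 50000 nM, which is a limit and not a number, so the step has a floor but no exact size: the limit of > 50000 nM in this assay, at which 1 of the 3 values shown sits. Both groups have the same hydrogen-bond donor and acceptor counts, while the ring goes from aromatic to non-aromatic.

The compounds shown leave open what an amine or a carboxylic acid in place of the hydroxyl on the 4-hydroxycyclohexyl group would give. They also leave open whether the opposite arrangement at its two defined stereocentres would read the same.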